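This account rests on a few compounds, and the source may have more. Where it says the series, first, only, none or still open, it means among the compounds named here.

Measured in a functional assay on HepG2 cells (Homo sapiens) for antiproliferative activity, read by CCK-8 assay, with a stated time of 48 h; on this read-out lower numbers stand for stronger inhibition and higher numbers for weaker inhibition:
- Compound 1 `COc1ccc(/C=C\c2cc(OC)c(OC)c(OC)c2)cc1OCc1ccc(CN2C[C@H](O)C[C@@H]2C(=O)O)cc1`: > 10000 nM, a limit of the assay
- Compound 2 `COc1ccc(/C=C\c2cc(OC)c(OC)c(OC)c2)cc1OCc1ccc(CN2CCCCC2C(=O)O)cc1`: 3100 nM
- Compound 3 `COc1ccc(/C=C\c2cc(OC)c(OC)c(OC)c2)cc1OCc1ccc(CO)cc1`: 2400 nM

Compound 3 cannot be told apart from compound 2, as the data show a 1.3-fold lower number from compound 2 to compound 3 (0.11 log units; within the scatter). Compound 3 also stands clear of the limit, with an at least 4.1-fold lower number from compound 1 to compound 3 (0.61 log units; beyond the scatter).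

Compound 4 `COc1ccc(/C=C\c2cc(OC)c(OC)c(OC)c2)cc1OCc1ccc(CNCCNC(C)=O)cc1` carries (2-acetamidoethyl)amino in place of hydroxy on a saturated chain carbon bound to an aromatic carbon.

Two measured exchanges touch this carbon, and they disagree in size, so neither predicts this new group closely. With the nearer comparison, compound 2, showing no real change, little movement in this assay is expected. The estimated change is a 1.3-fold higher number from compound 3 to compound 4 (0.10 log units; within the scatter), with a wide margin of doubt.

Compound 4 is expected at 3000 nM, within an estimated range of 900 nM to 9000 nM.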

Compound 4, half-maximal inhibitory concentration: 6100 nM
Compound 4: the middle estimate sits 2.0-fold (0.31 log units) below what was measured, and the stated range covers the measured number.
By their numbers in this assay, from the lowest: compounds 3, 2 and 4 (each within the scatter of the next, the first and the last beyond it). At a limit, above all of these: compound 1.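

Replacing hydroxy with the non-ring (2-acetamidoethyl)amino in this assay gives a 2.5-fold higher number from compound 3 to compound 4 (0.41 log units; beyond the scatter), so this saturated chain carbon does not tolerate every group without some loss. Compound 2 and compound 4 cannot be told apart, with a 2.0-fold higher number from compound 2 to compound 4 (0.29 log units; within the scatter). Compound 1 stands at a limit of the assay, so the step to the new chain, an at least 1.6-fold lower number from compound 1 to compound 4 (0.21 log units; that floor lies within the scatter), gives only a floor.

From the compounds shown here alone, whether a simple primary amine or a shorter chain ending in a carboxylic acid would stay close to compound 3 remains open. Also open, going by these compounds, is whether the acetamido end or the amino nitrogen accounts for the step from hydroxy.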